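A few compounds are considered here, and "the series" means these few. Any claim that something is new, unique, unknown or untested is made for them only; others in the source may bear on it.

Working notes on the series. Compound 2 `CCCn1c(=O)[nH]c2nc(-c3cnn(Cc4ccccc4)c3)[nH]c2c1=O` carries a propyl chain on the shared core and gives 13 nM in an assay on HEK293 cells for displacement of a labelled ligand from adenosine receptor A2b (Homo sapiens); on this read-out lower numbers stand for stronger inhibition and higher numbers for weaker inhibition. Compound 3 `CCCCn1c(=O)[nH]c2nc(-c3cnn(Cc4cccc(C(F)(F)F)c4)c3)[nH]c2c1=O` extends the chain to butyl and adds a trifluoromethyl group to the benzyl ring; in this assay compound 3 gives 30 nM, the higher of the two numbers measured, with compound 2 lower by a margin beyond the scatter. Compound 1 `CC(C)Cn1c(=O)[nH]c(=O)c2[nH]c(-c3cnn(Cc4ccccc4)c3)nc21`, built on a differently joined core, reaches only the limit of this assay: > 6000 nM, a limit rather than a number, as noted in the limit of > 6000 nM in this assay, at which 1 of the 3 values shown sits.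

Compound 4 `CC(C)Cn1c(=O)[nH]c2nc(-c3cnn(Cc4cccc(C(F)(F)F)c4)c3)[nH]c2c1=O` is the next entry, not yet measured. It differs from compound 3 by isopropyl in place of propyl on a saturated chain carbon bound to an aromatic nitrogen. For the measured compounds named here, no step between measured compounds bears on this change, so no direction is established from the data. Compound 4 is expected to sit close to compound 3, with a step of a 1.7-fold higher number from compound 3 to compound 4 (0.22 log units; within the scatter) that stays within the usual scatter. The estimate for compound 4 in this assay is 50 nM, ranging from 15 nM to 160 nM.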

Compound 4, inhibition constant: 28 nM
The estimate for compound 4 lay 1.8-fold (0.25 log units) above the measured number; measured number inside the range.
By their numbers in this assay, from the lowest: compound 2; then compounds 4 and 3 (each within the scatter of the next). At a limit, above all of these: compound 1.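

Isopropyl in place of propyl on a saturated chain carbon bound to an aromatic nitrogen gives a 1.1-fold lower number from compound 3 to compound 4 (0.03 log units; within the scatter) in this assay, so the two compounds cannot be told apart on this read-out. For the compounds shown here, this is the first step that isolates a single change at this position, and with the trifluoromethyl-substituted benzyl group held fixed, this branched chain gives a step that stays within the scatter. Nothing measured here bears on why the step is this small.

As far as these compounds go, whether the same change reads alike on a benzyl ring without the trifluoromethyl group remains open. Also open, from the compounds shown here alone, is how this position responds to a longer chain such as hexyl, or to a chain ending in an amine or a carboxylic acid.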